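A few compounds are considered here, and "the series" means these few. Any claim that something is new, unique, unknown or untested is made for them only; others in the source may bear on it.

Compound 1, `CNc1ncnc2c(CNc3cc(NC(=O)c4cc(C(F)(F)F)cc(C(F)(F)F)c4)ccc3C)cccc12`, gives 769 nM.
Compound 2, `CNc1ncnc2c(CNc3cc(NC(=O)c4ccc(-c5cc(C(F)(F)F)ccc5Cl)o4)ccc3C)cccc12`, gives 14900 nM.
Compound 3, `CNc1ncnc2c(CNc3cc(NC(=O)c4ccc(Br)s4)ccc3C)cccc12`, gives 10500 nM.

These three compounds share one core and differ only in the group attached to the amide carbonyl. They were tested in a functional assay on A375P cells (Homo sapiens) for cytotoxicity, read by MTT assay, with a stated time of 24 h; on this read-out lower numbers stand for stronger inhibition and higher numbers for weaker inhibition. Among the three numbers, compound 3 stands second highest. Its nearest neighbour is compound 2, whose number is within the usual scatter of it, so the two cannot be told apart. Compound 1 stands far lower, and that gap lies beyond the scatter.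

Compound 4, `CNc1ncnc2c(CNc3cc(NC(=O)c4cc(=O)c5ccccc5o4)ccc3C)cccc12`, is the next step from compound 3. The change is a group of 11 heavy atoms (9 carbon, 2 oxygen; one six-membered aromatic ring of carbon only, one six-membered aromatic ring with 1 hetero atom) in place of a group of 6 heavy atoms (4 carbon, 1 sulfur, 1 bromine; one five-membered aromatic ring with 1 hetero atom), on a carbonyl carbon. For the measured compounds named here, no measured pair among the three compounds makes this same change, so the expected outcome rests only on the spread seen so far: compound 1 shows that a different aromatic group on this carbonyl can carry a much lower number, while compound 2 and compound 3 sit together at the high end.

On this basis, compound 4 is expected to land close to compound 3, with the step from compound 3 to compound 4 estimated as a 1.3-fold lower number from compound 3 to compound 4 (0.12 log units; within the scatter), not beyond the scatter. The estimate for compound 4 in this assay is 8000 nM, with a range from 2000 nM to 30000 nM.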

Compound 4, half-maximal inhibitory concentration: 6 nM
Compound 4: middle estimate off by 1300-fold (3.12 log units), on the high side; the measured number lies below the stated range.
By their numbers in this assay, from the lowest: compound 4; then compound 1; then compounds 3 and 2 (each within the scatter of the next).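

In this assay, the group on the amide carbonyl can shift the number far more than compound 1, compound 2 and compound 3 had suggested: replacing the 5-bromothiophen-2-yl with the group of 11 heavy atoms gives a 1800-fold lower number from compound 3 to compound 4 (3.24 log units; beyond the scatter). For the compounds shown here, compound 1 had given the lowest number so far at 769 nM, and compound 4 now gives 6 nM, so this single position can carry a very low number in these cells while the rest of the molecule stays the same. Size alone does not sort these compounds, since compound 2 also carries a large group on this carbonyl and gives 14900 nM, and nothing available here explains why the group in compound 4 performs so differently.

Going by these compounds, it remains open which part of the new group matters, for instance whether a plain phenyl ring or a group bearing a carboxylic acid on this carbonyl would keep the number as low. A cell-killing read-out also cannot show through which target or route compound 4 acts on these cells.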